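A few compounds are considered here, and "the series" means these few. Any claim that something is new, unique, unknown or untested is made for them only; others in the source may bear on it.

The measured compounds:
Compound 1, `Cc1cc(C)nc(NS(=O)(=O)c2ccc(Nc3nncc4ccccc34)cc2)n1`: 7.6 nM
Compound 2, `NS(=O)(=O)c1ccc(Nc2nncc3ccccc23)cc1`: 33 nM
Compound 3, `O=S(=O)(Nc1nccs1)c1ccc(Nc2nncc3ccccc23)cc1`: 45 nM

All three were tested in a functional assay on SF-268 cells (Homo sapiens) for antiproliferative activity, read by sulforhodamine B assay, with a stated time of 72 h; on this read-out higher numbers stand for weaker inhibition and lower numbers for stronger inhibition. Compound 3 stands at the highest of the three numbers. The step of a 1.4-fold higher number from compound 2 to compound 3 (0.13 log units; within the scatter) is within the scatter, whereas the step of a 5.9-fold higher number from compound 1 to compound 3 (0.77 log units; beyond the scatter) is beyond the scatter. Compound 4, `O=S(=O)(Nc1ncccn1)c1ccc(Nc2nncc3ccccc23)cc1`, has not yet been measured. The change from compound 3 to compound 4 is pyrimidin-2-yl in place of 1,3-thiazol-2-yl on a sulfonamide nitrogen.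

Among the compounds with values here, two measured steps bear on this change. The step of a 5.9-fold higher number from compound 1 to compound 3 (0.77 log units; beyond the scatter) shows that exchanging the 4,6-dimethylpyrimidin-2-yl of compound 1 for 1,3-thiazol-2-yl raised the number by a modest, clearly visible amount. The step of a 4.3-fold higher number from compound 1 to compound 2 (0.64 log units; beyond the scatter) shows a similar rise when that group is taken away altogether. Compound 4 carries the pyrimidin-2-yl ring of compound 1 without its methyl groups, so it is expected to recover part of that difference. The step expected in this assay is therefore a modest lowering, a 2.3-fold lower number from compound 3 to compound 4 (0.35 log units; beyond the scatter). Compound 4 is estimated at 20 nM, with a range from 7 nM to 60 nM.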

Compound 4, half-maximal inhibitory concentration: 34 nM
Beside the measured number, compound 4's estimate is 1.7-fold (0.23 log units) below it; the range from low to high includes it.
By their numbers in this assay, from the lowest: compound 1; then compounds 2, 4 and 3 (each within the scatter of the next).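

In this assay, within the data shown here, the exchange of 1,3-thiazol-2-yl for pyrimidin-2-yl on the sulfonamide nitrogen left no step that can be read (a 1.3-fold lower number from compound 3 to compound 4 (0.12 log units; within the scatter)), and pyrimidin-2-yl could not be told apart from plain hydrogen at this position either (a 1.0-fold higher number from compound 2 to compound 4 (0.01 log units; within the scatter)). The earlier compounds shown here left open whether the pyrimidin-2-yl ring itself went with the lower number of compound 1, and this result answers that: without the 4,6-dimethyl substitution the ring does not keep it (a 4.5-fold higher number from compound 1 to compound 4 (0.65 log units; beyond the scatter)). Among these four compounds, then, the step beyond the scatter goes with the 4,6-dimethyl substitution, while compound 2, compound 3 and compound 4 stay within the scatter of one another, and no measurement at hand explains this.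

The compounds shown leave open whether a single methyl on the pyrimidin-2-yl ring would bring part of that lowering, and whether methoxy or a longer chain such as ethyl could stand in place of the methyl groups. They also leave open how a phenyl ring, which carries no ring nitrogen, would behave on the same sulfonamide nitrogen.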